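Triazole series: moving the nitro group on the benzyl ring

A few compounds are considered here, and "the series" means these few. Any claim that something is new, unique, unknown or untested is made for them only; others in the source may bear on it.

Measured so far in a functional assay on HepG2 cells (Homo sapiens) for inhibition, read by MTT assay, with a stated time of 48 h; a higher number here means a weaker inhibitor, a lower number a stronger inhibitor:
compound 1 `Clc1cccc(CSc2nnc(-c3ccncc3)n2-c2ccccc2)c1` gives 11200 nM.
compound 2 `Fc1cccc(F)c1CSc1nnc(-c2ccncc2)n1-c1ccccc1` gives > 50000 nM, a limit of this assay and not a number.
compound 3 `O=[N+]([O-])c1ccccc1CSc1nnc(-c2ccncc2)n1-c1ccccc1` gives > 50000 nM, again a limit of this assay and not a number.

Compound 3 therefore sits at the top edge of what this assay reports; the relevant feature is the limit of > 50000 nM in this assay, at which 2 of the 3 values shown sit. Within the data shown here, compound 1 is the only member with a numerical value, and the change from it to compound 3 gave an at least 4.4-fold higher number from compound 1 to compound 3 (0.64 log units; beyond the scatter), while the swap in compound 2 gave an at least 4.4-fold higher number from compound 1 to compound 2 (0.64 log units; beyond the scatter). The comparison of compound 2 with compound 3 is a step that the two limits leave unreadable from compound 2 to compound 3.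

Compound 4 `O=[N+]([O-])c1cccc(CSc2nnc(-c3ccncc3)n2-c2ccccc2)c1` is not yet measured. It differs from compound 3 by 3-nitrophenyl in place of 2-nitrophenyl on a saturated chain carbon bound to a sulfur. Among the measured compounds shown here, no measured step covers this particular move of the nitro group; the closest guide is compound 1, whose 3-chlorophenyl also sits on the saturated chain carbon bound to a sulfur and which gives 11200 nM in this assay. Compound 4 is thus expected to land between that numerical value and the limit, with a real chance it remains a limit. The estimate for compound 4 in this assay is 25000 nM, within 7000 nM to 50000 nM. This estimate implies a step of an at least 2.0-fold lower number from compound 3 to compound 4 (0.30 log units; that floor lies within the scatter), toward a stronger inhibitor, expected but uncertain.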

Compound 4, half-maximal inhibitory concentration: 22000 nM
For compound 4 the middle estimate is 1.1-fold (0.06 log units) above the measured one, and the stated range covers the measured number.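

In this assay, 3-nitrophenyl on the saturated chain carbon bound to a sulfur gives a readable value where 2-nitrophenyl gives only a limit, so the place of the nitro on this ring counts (an at least 2.2-fold lower number from compound 3 to compound 4 (0.35 log units; beyond the scatter)). The same swap from 2,6-difluorophenyl shows a step of the same kind (an at least 2.2-fold lower number from compound 2 to compound 4 (0.35 log units; beyond the scatter)). Nitro in place of chloro on an aromatic carbon stays within the scatter (a 2.0-fold higher number from compound 1 to compound 4 (0.29 log units; within the scatter)), so compound 1 and compound 4 cannot be told apart here.

Compound 2 and compound 3 each carry a limit and not a number, so the step between them cannot be read: the limit of > 50000 nM in this assay, at which 2 of the 4 values shown sit.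

Going by these compounds, whether an amine or a carboxylic acid in place of the nitro keeps a readable value in this assay stays open.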